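This account rests on a few compounds, and the source may have more. Where it says the series, first, only, none or still open, it means among the compounds named here.

The study turns on a functional assay on HCT-116 cells (Homo sapiens) for inhibition, read by colorimetric assay, with a stated time of 3 days; a lower number here means a stronger inhibitor, a higher number a weaker inhibitor. Compound 1, `O=C(CCCCCCNC(=O)C(O)(O)C(F)(F)F)Nc1ncc(-c2ccccc2)s1`, gives 2660 nM in this assay. Compound 2, `O=C(CCCCCCNC(=O)C(O)(O)C(F)(F)F)Nc1ccc(C(=O)c2ccccc2)cc1`, reaches only a limit in this assay, > 40000 nM. Compound 3, `OC(c1c(F)c(F)c(-n2cc(-c3ccccc3)nn2)c(F)c1F)C(F)(F)F`, likewise reaches only a limit in this assay, > 100000 nM. Compound 3 thus stands at the weak end of the three results shown: its result is the limit of > 100000 nM in this assay, at which 1 of the 3 values shown sits, the other limit is the limit of > 40000 nM in this assay, at which 1 of the 3 values shown sits, and compound 1 alone returns a number.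

The step to compound 4, `OC(O)(c1c(F)c(F)c(-n2cc(-c3ccccc3)nn2)c(F)c1F)C(F)(F)F`, is a single change: hydroxy in place of hydrogen on a saturated chain carbon bound to an aromatic carbon, an oxygen on a saturated carbon and a saturated chain carbon. Among the compounds with values here, no measured pair in the set carries this exact change, so its size cannot be read from a measured step. What can be seen is that compound 1 and compound 2 both already bear the 2,2,2-trifluoro-1,1-dihydroxyethyl group and show very different results, one a number and one a limit.

Compound 4 is expected to move toward stronger inhibition, with the step from compound 3 to compound 4 estimated at an at least 3.3-fold lower number from compound 3 to compound 4 (0.52 log units; beyond the scatter), while a further limit remains quite possible. Compound 4 is estimated at 30000 nM, expected to fall between 3000 nM and 100000 nM.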

Compound 4, half-maximal inhibitory concentration: > 100000 nM
Compound 4: no number, only a limit (the forecaster's own chance of this, stated with the estimate: 45%); middle value at least 3.3-fold (0.52 log units) from the limit.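

In this assay compound 4 returns only a limit (> 100000 nM). Within the data shown here, compound 3 also stands at a limit (> 100000 nM), so no step between compound 3 and compound 4 can be read. The compounds shown leave open whether, and how far, the change from 2,2,2-trifluoro-1-hydroxyethyl to 2,2,2-trifluoro-1,1-dihydroxyethyl moves inhibition on this core.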